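Swapping the Ring-Bearing Side Chain for 1-Methylbutyl

A few compounds are considered here, and "the series" means these few. Any claim that something is new, unique, unknown or untested is made for them only; others in the source may bear on it.

The study concerns three measured compounds that share one core, all tested in an assay for binding affinity to Corticotropin releasing factor receptor (Rattus norvegicus); on this read-out higher numbers stand for weaker inhibition and lower numbers for stronger inhibition. Compound 1 `CCCC(C)n1c(CC)nc2c(-c3ccc(OC)cc3C)ccnc21` gives 0.8 nM in this assay. Compound 3 `CCCC(C)n1c(CC)nc2c(-c3ccc(S(C)(=O)=O)cc3C(F)(F)F)ccnc21` gives 6.8 nM. Compound 2 `CCc1nc2c(-c3ccc(Cl)cc3Cl)ccnc2n1C(CCOC)C1CCC1` gives 2.4 nM, which places it second highest of the three numbers: its nearest neighbour is compound 3, whose number is higher by a gap beyond the scatter, and its furthest is compound 1, whose number is lower by a gap that also lies beyond the scatter.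

Compound 4 `CCCC(C)n1c(CC)nc2c(-c3ccc(Cl)cc3Cl)ccnc21` has not yet been measured. It differs from compound 2 in one place: 1-methylbutyl in place of 1-cyclobutyl-3-methoxypropyl on an aromatic nitrogen. Going by the values given here, no pair of measured compounds differs in exactly one place, so no measured step speaks directly to this change. Compound 1 carries 1-methylbutyl on that aromatic nitrogen and gives 0.8 nM; compound 3 carries the same group and gives 6.8 nM. The writer therefore expects the step of a 1.5-fold lower number from compound 2 to compound 4 (0.18 log units; within the scatter) to stay within the scatter, with no clear direction. For compound 4 the estimated value in this assay is 1.6 nM, with a range from 0.5 nM to 5 nM.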

Compound 4, inhibition constant: 0.5 nM
For compound 4 the middle estimate is 3.2-fold (0.51 log units) above the measured one; measured number inside the range.
By their numbers in this assay, from the lowest: compounds 4 and 1 (each within the scatter of the next); then compound 2; then compound 3.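

With the rest of the molecule unchanged, the exchange of 1-cyclobutyl-3-methoxypropyl for 1-methylbutyl on an aromatic nitrogen can now be read directly, as a 4.8-fold lower number from compound 2 to compound 4 (0.68 log units; beyond the scatter) in this assay and thus as a real change at this position. The smaller entering chain has no ring and no hydrogen-bond acceptor, so for this pair neither the four-membered ring nor the oxygen of the leaving group is required for the lower number. Nothing measured here explains the step or separates the contribution of the ring from that of the oxygen.

On these data alone, a 1-cyclobutylpropyl group, which would keep the ring without the oxygen, and a longer chain such as 1-methylpentyl remain open at this nitrogen. As far as these compounds go, it also remains open whether the same exchange would give a similar step with the other substituents carried by compound 1 and compound 3.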